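This account rests on a few compounds, and the source may have more. Where it says the series, first, only, none or still open, it means among the compounds named here.

Compound 1 `Cc1ccc(C2(CNC(=O)Nc3c(C(C)C)cccc3C(C)C)CCCC2)cc1` gives 25 nM in an assay on microsomes for inhibition of acyl-CoA:cholesterol acyltransferase (Oryctolagus cuniculus) (on this read-out lower numbers stand for stronger inhibition and higher numbers for weaker inhibition), the lowest of the two numbers in hand. Compound 2 `CC(C)c1cccc(C(C)C)c1NC(=O)NCC1(c2ccc(CC(C)(C)C)cc2)CCCC1` gives 159 nM in this assay, reached through a 6.4-fold higher number from compound 1 to compound 2 (0.80 log units; beyond the scatter). Compound 3 `COc1cccc(C2(CNC(=O)Nc3c(C(C)C)cccc3C(C)C)CCCC2)c1` differs from compound 1 by 3-methoxyphenyl in place of 4-methylphenyl on a saturated ring carbon. For the measured compounds named here, no measured step alters the 4-methylphenyl in just this way; the single measured step changed a different group and was modest, so a modest step in this assay toward a higher number is expected for compound 3. Compound 3 is estimated at 50 nM in this assay, with a range from 15 nM to 170 nM. That estimate corresponds to an expected 2.0-fold higher number from compound 1 to compound 3 (0.30 log units; within the scatter).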

Compound 3, half-maximal inhibitory concentration: 13 nM
Estimate against measurement, compound 3: 3.8-fold (0.59 log units) above; measured number outside the range, below it.
By their numbers in this assay, from the lowest: compounds 3 and 1 (each within the scatter of the next); then compound 2.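

On the saturated ring carbon in this assay the swap of 4-methylphenyl for 3-methoxyphenyl gives a 1.9-fold lower number from compound 1 to compound 3 (0.28 log units; within the scatter) and so leaves the two groups indistinguishable, although the entering group adds a hydrogen-bond acceptor. The same place also shows a wide span, with a 12-fold lower number from compound 2 to compound 3 (1.09 log units; beyond the scatter) on replacing 4-neopentylphenyl by 3-methoxyphenyl. No evidence at hand bears on either step. On these data alone, whether an amine, a carboxylic acid or chlorine on the phenyl ring would keep the number in this assay stays open, as does how much of this swap belongs to the methoxy group and how much to where it sits.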